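Cyclopropyl in place of methyl: working notes

The compounds below may be only part of what the source reports. "The series", "measured", "known", "first", "only" and "open" are said of these compounds alone.

In a functional assay on OCI-Ly3 cells (Homo sapiens) for antiproliferative activity (a lower number here means that less compound is needed, a higher number that more compound is needed for the effect), compound 3 `Cc1c(NC(=O)Nc2cnc(-n3nccn3)c(Cl)c2)cnc2ccccc12` gives 7170 nM as the higher of the two actual numbers, and compound 2 `CO[C@@H](C)c1c(NC(=O)Nc2cnc(-n3nccn3)c(Cl)c2)cnc2cc(Cl)nn12` gives 120 nM on the same read-out. The gap between these two numbers lies beyond the scatter. Compound 1 `O=C(Nc1cnc(-n2nccn2)c(Cl)c1)Nc1cncc2ccccc12` has only a limit of > 20000 nM as its result. Compound 4 `O=C(Nc1cnc(-n2nccn2)c(Cl)c1)Nc1cnc2ccccc2c1C1CC1` differs from compound 3 by cyclopropyl in place of methyl on an aromatic carbon, opposite the ring nitrogen. Going by the values given here, no measured pair isolates this change, so the expectation is loose. The expected step of a 2.4-fold lower number from compound 3 to compound 4 (0.38 log units; beyond the scatter) in this assay is a modest one toward a lower number, possibly little beyond the scatter. The estimate for compound 4 is 3000 nM with 700 nM to 12000 nM as the expected range.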

Compound 4, half-maximal effective concentration: 1580 nM
Beside the measured number, compound 4's estimate is 1.9-fold (0.28 log units) above it, and the stated range covers the measured number.
By their numbers in this assay, from the lowest: compound 2; then compound 4; then compound 3. At a limit, above all of these: compound 1.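

In this assay, the step of a 4.5-fold lower number from compound 3 to compound 4 (0.66 log units; beyond the scatter) gives the series its first pair differing in one place. It shows that, at this position opposite the ring nitrogen, a three-membered carbon ring in place of methyl lowers the number beyond the scatter. The measurements shown offer nothing that accounts for this step.

From the compounds shown here alone, whether an amine or a longer chain such as propyl at this position would extend or reverse the step remains open. Also open, going by these compounds, is whether cyclopropyl in place of methyl would give a similar step on the core of compound 2.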